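The compounds below may be only part of what the source reports. "The series", "measured", "known", "first", "only" and "open" are said of these compounds alone.

In a functional assay on BT-474 cells (Homo sapiens) for inhibition, read by MTT assay, with a stated time of 5 days (on this read-out lower numbers stand for stronger inhibition and higher numbers for weaker inhibition), compound 1 `Cc1cc(Nc2nc(NCc3ccccc3Br)nc3[nH]ncc23)n[nH]1` gives 10100 nM, compound 2 `Cc1cc(Nc2nc(NCc3ccc(F)cc3)nc3[nH]ncc23)n[nH]1` gives 8750 nM and compound 3 `Cc1cc(Nc2nc(NCc3ccc(Cl)cc3)nc3[nH]ncc23)n[nH]1` gives 11700 nM. Compound 3 therefore stands level with the other two, as the steps show: a 1.2-fold higher number from compound 1 to compound 3 (0.06 log units; within the scatter) and a 1.3-fold higher number from compound 2 to compound 3 (0.13 log units; within the scatter). The next compound, compound 4 `Cc1cc(Nc2nc(NCc3ccc(F)cc3F)nc3[nH]ncc23)n[nH]1`, differs from compound 3 in one place: 2,4-difluorophenyl in place of 4-chlorophenyl on a saturated chain carbon bound to a nitrogen on an aromatic ring. It carries 2,4-difluorophenyl in place of 4-chlorophenyl. The nearest evidence is the swap of chloro for fluoro, a 1.3-fold higher number from compound 2 to compound 3 (0.13 log units; within the scatter), supported by the other change of this aromatic group, a 1.2-fold lower number from compound 1 to compound 2 (0.06 log units; within the scatter). Both stay within the scatter, so no step beyond it is expected. The estimated step is expected to be a 1.2-fold lower number from compound 3 to compound 4 (0.07 log units; within the scatter). Compound 4 is estimated at 10000 nM, with an expected range of 5000 nM to 20000 nM.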

Compound 4, half-maximal inhibitory concentration: 3220 nM
Estimate against measurement, compound 4: 3.1-fold (0.49 log units) above; measured number below the stated range.
By their numbers in this assay, from the lowest: compound 4; then compounds 2, 1 and 3 (each within the scatter of the next).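

For the compounds shown here, the 2,4-difluorophenyl group gives the first change at this position that lies beyond the scatter in this assay: a 3.6-fold lower number from compound 3 to compound 4 (0.56 log units; beyond the scatter) and a 3.1-fold lower number from compound 1 to compound 4 (0.50 log units; beyond the scatter) both mark it as a modest gain. Going by these compounds alone, the cleanest comparison is fluoro in place of hydrogen on an aromatic carbon, with a 2.7-fold lower number from compound 2 to compound 4 (0.43 log units; beyond the scatter) showing that one added fluoro changes the result although swapping the single halogen-bearing groups did not. No measurement here accounts for this gain. On these data alone, whether 2-fluorophenyl alone would match it remains open, as does the outcome with a methoxy group or an amine on this ring.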